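A few compounds are considered here, and "the series" means these few. Any claim that something is new, unique, unknown or untested is made for them only; others in the source may bear on it.

Compound 1 `Cc1ccc(N2CCN(CC(=O)N(c3ccccc3)c3ccccc3)CC2)cc1` was tested in a toxicity assay on the whole organism (strain albino) for activation, with Mus musculus as the target, with stated times of 30 min and 240 min; on this read-out lower numbers stand for an effect already at smaller amounts and higher numbers for an effect only at larger amounts of compound. In this assay compound 1 gives only a limit, > 40 mg/kg. Its standing is thus known as the limit of > 40 mg/kg in this assay, at which 1 of the 3 values shown sits, and not as a number. Two relatives keep the same core: compound 2 `COc1ccccc1N1CCN(CC(=O)N(c2ccccc2)c2ccccc2)CC1` gives 50.4 mg/kg, and compound 3 `COc1cccc(N2CCN(CC(=O)N(c3ccccc3)c3ccccc3)CC2)c1` gives 55.4 mg/kg. The steps a step that the limit leaves unreadable from compound 1 to compound 2 and a step that the limit leaves unreadable from compound 1 to compound 3 cannot be sized, whereas a 1.1-fold higher number from compound 2 to compound 3 (0.04 log units; within the scatter) stays within the scatter. Compound 4 `O=C(CN1CCN(c2ccc(Cl)c(Cl)c2)CC1)N(c1ccccc1)c1ccccc1` differs from compound 1 by 3,4-dichlorophenyl in place of 4-methylphenyl on an amine nitrogen in a ring. Going by the values given here, no measured step covers this exchange; compound 2 at 50.4 mg/kg and compound 3 at 55.4 mg/kg show where nearby substitutions have landed. Compound 4 is therefore expected near them, at an estimated 50 mg/kg with a range from 25 mg/kg to 100 mg/kg. The expected step that the limit leaves unreadable from compound 1 to compound 4 is not readable in size from the limit.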

Compound 4, dose for half-maximal effect: 45 mg/kg
The estimate for compound 4 lay 1.1-fold (0.05 log units) above the measured number, and the stated range covers the measured number.
By their numbers in this assay, from the lowest: compounds 4, 2 and 3 (each within the scatter of the next).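

In this assay, 3,4-dichlorophenyl on the amine nitrogen in the ring gives a 1.2-fold lower number from compound 3 to compound 4 (0.09 log units; within the scatter), and a 1.1-fold lower number from compound 2 to compound 4 (0.05 log units; within the scatter). Readable numbers at this position had so far come only from methoxyphenyl groups, and these steps show that a phenyl group carrying chlorine also stays within the scatter of them. Compound 1 gives only a limit, so its step to compound 4 cannot be read: the limit of > 40 mg/kg in this assay, at which 1 of the 4 values shown sits.

Going by these compounds, it remains open whether a pyridine ring or a benzyl group on this nitrogen, or an amine on the phenyl ring, would move the number beyond the scatter.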